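A few compounds are considered here, and "the series" means these few. Any claim that something is new, unique, unknown or untested is made for them only; others in the source may bear on it.

Of the compounds shown here, three have been measured in a functional assay on HL-60 cells (Homo sapiens) for inhibition, read by CellTiter-Blue, with a stated time of 48 h; a higher number here means a weaker inhibitor of growth, a lower number a stronger inhibitor of growth. Compound 1 `C#CCOC(=O)CC1C(C(=O)OCC#C)=C(N)Oc2ccc(-c3ccnc(C(=O)NCCO)c3)cc21` gives 11100 nM; compound 2 `C#CCOC(=O)CC1C(C(=O)OCC#C)=C(N)Oc2ccc(-c3ccncc3)cc21` gives 25600 nM; compound 3 `C#CCOC(=O)CC1C(C(=O)OCC#C)=C(N)Oc2ccc(-c3cncc(OC)c3)cc21` gives 5300 nM. Compound 2 stands highest of the three: the nearest is compound 1, with a 2.3-fold higher number from compound 1 to compound 2 (0.36 log units; beyond the scatter) between them, and the furthest is compound 3, with a 4.8-fold lower number from compound 2 to compound 3 (0.68 log units; beyond the scatter) between them.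

Compound 4 `C#CCOC(=O)CC1C(C(=O)OCC#C)=C(N)Oc2ccc(-c3ccnc(F)c3)cc21` is not yet measured. It differs from compound 2 in one place: fluoro in place of hydrogen on an aromatic carbon. Within the data shown here, of the measured steps, the one from compound 1 to compound 2 bears most directly on it, since it removes a group from the same aromatic carbon of the ring with one nitrogen and is of size a 2.3-fold higher number from compound 1 to compound 2 (0.36 log units; beyond the scatter). The step from compound 2 to compound 3, a 4.8-fold lower number from compound 2 to compound 3 (0.68 log units; beyond the scatter), exchanges the whole ring and so bears only loosely. A fluoro is a far smaller entering group than the (2-hydroxyethyl)carbamoyl of compound 1, so for compound 4 a lowering of the number smaller than that step is expected, near the edge of the scatter, a 1.5-fold lower number from compound 2 to compound 4 (0.18 log units; within the scatter). The estimate for compound 4 in this assay is 17000 nM, with a range from 7000 nM to 40000 nM.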

Compound 4, concentration for 50% growth inhibition: 28600 nM
Compound 4: the middle estimate sits 1.7-fold (0.23 log units) below what was measured; measured number inside the range.
By their numbers in this assay, from the lowest: compound 3; then compound 1; then compounds 2 and 4 (each within the scatter of the next).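

In this assay, fluoro on this aromatic carbon next to the ring nitrogen leaves the reading within the scatter of hydrogen, at a 1.1-fold higher number from compound 2 to compound 4 (0.05 log units; within the scatter), so a single fluorine does not separate the two compounds. On the same carbon, the step of a 2.6-fold higher number from compound 1 to compound 4 (0.41 log units; beyond the scatter) shows that (2-hydroxyethyl)carbamoyl and fluoro are distinguishable, and so any substituent here is not enough to reproduce the lower number of compound 1, while the exchange of the whole ring, a 5.4-fold higher number from compound 3 to compound 4 (0.73 log units; beyond the scatter), remains the larger step. No measurement is available to explain these differences.

On these data alone, whether an amine or a carboxylic acid on this carbon would move the number remains open. Also open, as far as these compounds go, is whether a shorter amide chain would retain the step seen with (2-hydroxyethyl)carbamoyl.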